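This account rests on a few compounds, and the source may have more. Where it says the series, first, only, none or still open, it means among the compounds named here.

In a functional assay on K562 cells (Homo sapiens) for inhibition, read by MTT assay, with a stated time of 48 h (a lower number here means a stronger inhibitor, a higher number a weaker inhibitor), compound 1 `CC(C)(C)OC(=O)N1C[C@@H](n2cc(-c3ccc4nc(N)sc4n3)nn2)C[C@H]1C(=O)Nc1ccc(Cl)cc1Cl` gives 8940 nM, compound 2 `CC(C)(C)OC(=O)N1C[C@@H](n2cc(-c3ccc4nc(N)sc4n3)nn2)C[C@H]1C(=O)Nc1ccc(Br)cc1` gives 29200 nM and compound 3 `CC(C)(C)OC(=O)N1C[C@@H](n2cc(-c3ccc4nc(N)sc4n3)nn2)C[C@H]1C(=O)Nc1ccc(F)c(F)c1` gives 26400 nM. Compound 3 therefore sits at the weak end of this small set, where the last two values are level: a 1.1-fold lower number from compound 2 to compound 3 (0.04 log units; within the scatter). Compound 4 `Nc1nc2ccc(-c3cn([C@@H]4CN[C@H](C(=O)Nc5ccc(F)c(F)c5)C4)nn3)nc2s1` carries one change: hydrogen in place of tert-butoxycarbonyl on an amine nitrogen in a ring. The other measured steps, a 3.3-fold higher number from compound 1 to compound 2 (0.51 log units; beyond the scatter) and a 3.0-fold higher number from compound 1 to compound 3 (0.47 log units; beyond the scatter), are modest, but they alter only the phenyl group on the amide-type nitrogen, so they offer a rough scale and no direction. In this assay the expected change is a loosely held modest rise, a 1.3-fold higher number from compound 3 to compound 4 (0.12 log units; within the scatter). Compound 4 is estimated at 35000 nM, within a range of 10000 nM to 100000 nM.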

Compound 4, half-maximal inhibitory concentration: 33200 nM
Compound 4: the middle estimate sits 1.1-fold (0.02 log units) above what was measured; the range from low to high includes it.
By their numbers in this assay, from the lowest: compound 1; then compounds 3, 2 and 4 (each within the scatter of the next).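

In this assay, hydrogen in place of tert-butoxycarbonyl on the amine nitrogen in the ring gives a 1.3-fold higher number from compound 3 to compound 4 (0.10 log units; within the scatter) and so stays within the usual scatter. The earlier steps shown here altered only the phenyl group on the amide-type nitrogen, whereas this one shows that losing 7 heavy atoms at this ring nitrogen leaves the two compounds indistinguishable here. Nothing measured here offers an explanation for this result.

A methyl, an acetyl or a longer chain on that nitrogen could still behave differently. Going by these compounds, it also remains open whether the same swap would leave compound 1, with its 2,4-dichlorophenyl group, equally unchanged.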